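A few compounds are considered here, and "the series" means these few. Any claim that something is new, unique, unknown or untested is made for them only; others in the source may bear on it.

In a functional assay on Hep 3B2 cells (Homo sapiens) for antiproliferative activity, read by MTT assay, with a stated time of 24 h, tested at 0.05 ug/mL (on this read-out higher numbers stand for a stronger effect at the one concentration tested and lower numbers for a weaker effect), compound 1, `CCc1ccc2nc(C(=O)Nc3c(F)cc(-c4cccc(F)c4)cc3F)c(C)c(C(=O)O)c2c1`, gives 0%. Compound 2, `Cc1c(C(=O)Nc2c(F)cc(-c3cccc(F)c3)cc2F)nc2ccc(F)cc2c1C(=O)O`, differs from it at one aromatic carbon of the shared core, and in this assay compound 2 gives 0.05%. The step of a number 0.1 percentage points higher from compound 1 to compound 2 (within the scatter) shows that swapping ethyl for fluoro at that position left the read-out essentially unchanged, and compound 2 thus sits alongside compound 1, both numbers being within the scatter of each other; neither compound shows any measurable effect at the single concentration tested.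

Compound 3, `CCOc1ccc2nc(C(=O)Nc3c(F)cc(-c4cccc(F)c4)cc3F)c(C)c(C(=O)O)c2c1`, is not yet measured. It differs from compound 2 as follows: ethoxy in place of fluoro on an aromatic carbon. Among the compounds with values here, the only measured step that bears on this position is the one from compound 1 to compound 2, and it was flat. With both known substituents at this carbon giving effectively no inhibition, the expected step of a number 1 percentage points higher from compound 2 to compound 3 (within the scatter) is none beyond the scatter. Compound 3 is therefore estimated to give 1% in this assay, with a range from 0% to 10%.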

Compound 3, a percentage reported as inhibition, at one concentration (the size of the read-out at that concentration, not a potency): 0.98%
Compound 3: the middle estimate sits 0 percentage points above what was measured; measured number inside the range.
By their numbers in this assay, from the lowest: compounds 1, 2 and 3 (each within the scatter of the next).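

Ethoxy brings a third kind of group to this aromatic carbon, with more heavy atoms than fluoro and an oxygen that counts as a hydrogen-bond acceptor, yet in this assay the change still gives a number 0.9 percentage points higher from compound 2 to compound 3 (within the scatter) and, set against ethyl, gives a number 1 percentage points higher from compound 1 to compound 3 (within the scatter). The earlier pair compared only fluoro and ethyl, neither of which has a hydrogen-bond acceptor, so the flat result now extends to a group that has one: among these three groups, the choice of substituent at this position makes no difference that can be told from the scatter at the single concentration tested. Nothing available here explains why the read-out stays so close to nothing. As far as these compounds go, whether an amine, a carboxylic acid or a longer chain such as butoxy on this carbon would lift the read-out remains open, as does whether a change elsewhere on the shared core would do so. From the compounds shown here alone, with all three numbers this near the bottom of the scale at one low concentration, it also remains open whether ethyl, fluoro and ethoxy would separate at a higher concentration.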